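Putting a three-membered ring into the chain of compound 2

The source may report more compounds than this note shows. Statements on the series, on what has been measured and on what is new or still open speak of the compounds shown alone.

Measured in an ADME assay on the whole organism (strain CD-1) for pharmacokinetics, with Mus musculus as the target, at a dose of 3 mg/kg by the intravenous route; a higher number here means faster removal of the compound, a lower number slower removal
- compound 1 `CN(Cc1ccccc1OCCCCC(C)(C)C(=O)O)C(=O)c1ccc(-c2ccco2)cc1` gives 1.3 mL/min/kg
- compound 2 `C[C@H](CCCOc1ccccc1CN(C)C(=O)c1ccc(-c2ccco2)cc1)CC(=O)O` gives 0.3 mL/min/kg

Compound 2 stands lowest of the two (0.3 mL/min/kg). Compound 3 `CN(Cc1ccccc1OCCC[C@@H]1C[C@H]1C(=O)O)C(=O)c1ccc(-c2ccco2)cc1` carries 2-carboxycyclopropyl in place of 1-(carboxymethyl)ethyl on a saturated chain carbon, three bonds along the chain from an oxygen on an aromatic ring. For the measured compounds named here, the one measured step at this place (a 4.3-fold lower number from compound 1 to compound 2 (0.64 log units; beyond the scatter)) is modest but beyond the scatter, and it is the only guide. Compound 3 is expected to show a modest rise in this assay (a 2.3-fold higher number from compound 2 to compound 3 (0.37 log units; beyond the scatter)). The estimated value for compound 3 is 0.7 mL/min/kg (expected range 0.25 mL/min/kg to 2.5 mL/min/kg).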

Compound 3, clearance: 0.6 mL/min/kg
Compound 3: middle estimate off by 1.2-fold (0.07 log units), on the high side; measured number inside the range.
By their numbers in this assay, from the lowest: compounds 2 and 3 (each within the scatter of the next); then compound 1.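

In this assay, 2-carboxycyclopropyl in place of 1-(carboxymethyl)ethyl gives (a 2.0-fold higher number from compound 2 to compound 3 (0.30 log units; within the scatter)), so at this position the three-membered ring and the open chain cannot be told apart. In place of 2-carboxy-2-methylpropyl, the same ring gives (a 2.2-fold lower number from compound 1 to compound 3 (0.34 log units; beyond the scatter)), so a second group now stands clear of the scatter from that one. No measurement here explains these numbers.

The compounds shown leave open how a four-membered ring or a longer chain would read at this place, and whether a tetrazole could stand in for the carboxylic acid.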